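A few compounds are considered here, and "the series" means these few. Any claim that something is new, unique, unknown or untested is made for them only; others in the source may bear on it.

Compound 1 `CCC(C)SSC(=S)N(CC)CC` is reported in an ADME assay on MCF-10A cells (Homo sapiens) for antiproliferative activity, read by MTT assay, with a stated time of 72 h (a higher number here means a weaker inhibitor, a lower number a stronger inhibitor), only as a limit, > 10000 nM. Compound 2 `CCN(CC)C(=S)SSC1CCCCC1` is likewise reported in this assay only as a limit, > 10000 nM. Compound 2 therefore stands at the limit of > 10000 nM in this assay, at which 2 of the 2 values shown sit, with no number of its own. Compound 3 `S=C(SSC1CCCCC1)N1CCCC1` is yet to be measured in this assay; it differs from compound 2 by pyrrolidin-1-yl in place of diethylamino on a thiocarbonyl carbon. Among the measured compounds shown here, no step between measured compounds exists here, so no shift beyond the usual scatter is expected in this assay for this change. For compound 3 the expected value in this assay is 20000 nM (8000 nM to 50000 nM), most probably again reported as a limit. The expected step that the limit leaves unreadable from compound 2 to compound 3 is accordingly small.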

Compound 3, half-maximal inhibitory concentration: > 10000 nM
Compound 3 ended at the assay's limit; the forecaster's own chance of this, stated with the estimate: 85%; the middle value is on the limit's open side.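

Compound 2 and compound 3 both end as limits in this assay, so no step between them can be read: the limit of > 10000 nM in this assay, at which 3 of the 3 values shown sit.

The compounds shown leave open what, if anything, in this series gives a true number in this assay.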